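A few compounds are considered here, and "the series" means these few. Any claim that something is new, unique, unknown or untested is made for them only; others in the source may bear on it.

Measured so far:
Compound 1 `OCC#CCSc1cnc2ccccc2c1[Se]CC#CCO`, 1.4 ug/mL
Compound 2 `COc1c(SCC#CCO)cnc2ccccc12`, 22 ug/mL
Compound 3 `C#CC[Se]c1c(SCC#CCO)cnc2ccccc12`, 1.9 ug/mL

These numbers come from a functional assay on CCRF-CEM cells (Homo sapiens) for cytotoxicity, read by sulforhodamine B assay, with a stated time of 72 h; on this read-out higher numbers stand for weaker inhibition and lower numbers for stronger inhibition. Compound 3 stands second highest of the three; its nearest neighbour is compound 1, separated by a step within the scatter (a 1.4-fold higher number from compound 1 to compound 3 (0.13 log units; within the scatter)), while compound 2 lies far off (a 12-fold lower number from compound 2 to compound 3 (1.06 log units; beyond the scatter)). Compound 4 `C#CCSc1c(SCC#CCO)cnc2ccccc12` differs from compound 3 in one place: a group of 4 heavy atoms (3 carbon, 1 sulfur; no ring) in place of a group of 4 heavy atoms (3 carbon, 1 selenium; no ring), on an aromatic carbon. Among the measured compounds shown here, no measured step exchanges selenium for sulfur, so no step bears directly on this change. The large steps seen so far (a 16-fold higher number from compound 1 to compound 2 (1.20 log units; beyond the scatter) and a 12-fold lower number from compound 2 to compound 3 (1.06 log units; beyond the scatter)) come from removing or adding the whole chain, not from changing one atom within it. The step of a 1.6-fold higher number from compound 3 to compound 4 (0.20 log units; within the scatter) is therefore expected to stay within the scatter. Compound 4 is estimated at 3 ug/mL, with a range from 1 ug/mL to 10 ug/mL.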

Compound 4, concentration for 50% inhibition: 2.7 ug/mL
For compound 4 the middle estimate is 1.1-fold (0.05 log units) above the measured one; the range from low to high includes it.
By their numbers in this assay, from the lowest: compounds 1, 3 and 4 (each within the scatter of the next); then compound 2.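

Sulfur can stand in for selenium at this position on the core: in this assay, a 1.4-fold higher number from compound 3 to compound 4 (0.15 log units; within the scatter) separates the two chains by no more than the usual scatter. Selenium is also not needed for the gain over methoxy, since an 8.1-fold lower number from compound 2 to compound 4 (0.91 log units; beyond the scatter) is seen with propargylsulfanyl. The shorter sulfur chain also holds up against the selenium chain with a hydroxymethyl end, with a 1.9-fold higher number from compound 1 to compound 4 (0.29 log units; within the scatter) again within the scatter.

Nothing shown explains why these chains perform alike. As far as these compounds go, whether an amine or a longer chain here would keep this level remains open.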